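This account rests on a few compounds, and the source may have more. Where it says the series, first, only, none or still open, it means among the compounds named here.

Measured in a functional assay on MiaPaCa cells (Homo sapiens) for antiproliferative activity, read by sulforhodamine B assay, with a stated time of 48 h; on this read-out higher numbers stand for weaker inhibition of growth and lower numbers for stronger inhibition of growth:
- compound 1 `COc1ccc(-c2cn(CCCN3C(=O)COc4ccccc43)nn2)cc1`: 15700 nM
- compound 2 `CCCCCCc1cn(CCCN2C(=O)COc3ccccc32)nn1`: 150 nM
- compound 3 `CCCCc1cn(CCCN2C(=O)COc3ccccc32)nn1`: 2500 nM

Compound 1 has the highest number of the three and is therefore the weakest growth inhibitor in this small set. Its nearest neighbour is reached by a 6.3-fold lower number from compound 1 to compound 3 (0.80 log units; beyond the scatter), and its furthest by a 100-fold lower number from compound 1 to compound 2 (2.02 log units; beyond the scatter).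

Compound 4 `O=C1COc2ccccc2N1CCCn1cc(CCCCl)nn1` keeps the core of compound 1 and changes one group on an aromatic carbon, with 3-chloropropyl in place of 4-methoxyphenyl on an aromatic carbon.

Two measured steps make the same kind of exchange, an open chain for 4-methoxyphenyl, and both lowered the number. The butyl chain gave a 6.3-fold lower number from compound 1 to compound 3 (0.80 log units; beyond the scatter), a modest step, while the hexyl chain gave a 100-fold lower number from compound 1 to compound 2 (2.02 log units; beyond the scatter), a large one. Chain length clearly matters here, as a 17-fold higher number from compound 2 to compound 3 (1.22 log units; beyond the scatter) shows. As far as these compounds go, no chlorine-bearing chain has been measured, so the chlorine remains untested. The 3-chloropropyl chain resembles butyl more than hexyl, so a modest drop in the number is expected, comparable to the butyl step and in the same direction. The expected change is a 6.3-fold lower number from compound 1 to compound 4 (0.80 log units; beyond the scatter). For compound 4 the estimated value is 2500 nM, with an expected range from 700 nM to 9000 nM.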

Compound 4, concentration for 50% growth inhibition: 12500 nM
Estimate against measurement, compound 4: 5.0-fold (0.70 log units) below, and the stated range ends below it.
By their numbers in this assay, from the lowest: compound 2; then compound 3; then compounds 4 and 1 (each within the scatter of the next).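

At this aromatic carbon of the five-membered ring, in this assay, 3-chloropropyl and 4-methoxyphenyl cannot be told apart (a 1.3-fold lower number from compound 1 to compound 4 (0.10 log units; within the scatter)), so an open chain in place of 4-methoxyphenyl does not always bring the clear drop seen with the butyl and hexyl chains. The end of the chain therefore counts as well as its presence, since chloro in place of methyl on the chain gives a clear rise (a 5.0-fold higher number from compound 3 to compound 4 (0.70 log units; beyond the scatter)) and chloro in place of propyl gives a much larger one (an 83-fold higher number from compound 2 to compound 4 (1.92 log units; beyond the scatter)). Nothing available explains why the chlorine-bearing chain stands apart from the two plain chains.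

Left open is whether a pentyl or octyl chain would extend the run from butyl to hexyl, and whether a hydroxyl, an amine or a nitrile at the end of the three-carbon chain would behave as the chlorine does. Also open is whether a chlorine at the end of a hexyl chain would cost as much, as the compounds shown carry chlorine only on the 3-chloropropyl chain.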